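The source may report more compounds than this note shows. Statements on the series, on what has been measured and on what is new or still open speak of the compounds shown alone.

Within the data shown here, compound 1 `Cc1ccccc1N(C)C(=O)c1ccc(-c2ccc(OS(N)(=O)=O)cc2)o1` is the stronger of the two compounds measured so far: in an assay on T47D cells for inhibition of Steryl-sulfatase (Homo sapiens), read by HPLC, with a stated time of 24 h (a higher number here means a weaker inhibitor, a lower number a stronger inhibitor), compound 1 gives 28 nM, while compound 2 `Cc1ccccc1N(C)C(=O)c1ccc(-c2cccc(OS(N)(=O)=O)c2)o1` gives 690 nM, a gap well beyond the usual scatter. Compound 3 `Cc1ccccc1N(C)C(=O)c1ccc(-c2ccc(OS(N)(=O)=O)c(Cl)c2)o1` differs from compound 1 by chloro in place of hydrogen on an aromatic carbon. No step of this kind has been measured among these compounds, so the expectation rests on compound 1 alone. Compound 3 is expected to stay close to compound 1, with an estimated step of a 1.4-fold lower number from compound 1 to compound 3 (0.15 log units; within the scatter) that need not exceed the scatter. The estimate for compound 3 in this assay is 20 nM, within a range from 6 nM to 70 nM.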

Compound 3, half-maximal inhibitory concentration: 25 nM
Beside the measured number, compound 3's estimate is 1.3-fold (0.10 log units) below it; low and high end bracket the measured number.
By their numbers in this assay, from the lowest: compounds 3 and 1 (each within the scatter of the next); then compound 2.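

In this assay, chloro in place of hydrogen, ortho to a sulfamoyloxy group, gives a 1.1-fold lower number from compound 1 to compound 3 (0.05 log units; within the scatter) and so leaves compound 3 and compound 1 indistinguishable. Among these compounds, this is the first sign that this aromatic carbon accepts a substituent, here a single chlorine atom, without a change beyond the scatter. Nothing measured here explains this match. Going by these compounds, whether this holds for other groups at this position, such as methoxy, an amine or a carboxylic acid, remains open. So does whether a larger group, such as a longer alkyl chain, fits equally well.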